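Sulfonyl to sulfanyl: a measured step, an expected step

The compounds below may be only part of what the source reports. "The series", "measured", "known", "first", "only" and "open" are said of these compounds alone.

Compound 1, `CC(O)(CS(=O)(=O)c1ccc(F)cc1)c1nc(-c2ccc([N+](=O)[O-])c(C(F)(F)F)c2)no1`, in a functional assay on DU-145 cells (Homo sapiens) for cytotoxicity, read by MTT assay; a higher number here means a weaker inhibitor, a lower number a stronger inhibitor: > 100000 nM, a limit of this assay.
Compound 2, `CC(O)(CSc1ccc(F)cc1)c1nc(-c2ccc([N+](=O)[O-])c(C(F)(F)F)c2)no1`, in this assay: 5100 nM.
Compound 3, `CC(O)(CS(=O)(=O)c1ccccc1)c1nc(-c2ccc([N+](=O)[O-])c(C(F)(F)F)c2)no1`, in this assay: > 100000 nM, a limit of this assay.

Compound 3 stands at the limit of this assay, so its own position is known only as a bound; the same is true of compound 1, since (the limit of > 100000 nM in this assay, at which 2 of the 3 values shown sit). Compound 2 alone gives a number. The step from compound 1 to compound 2, an at least 19-fold lower number from compound 1 to compound 2 (1.29 log units; beyond the scatter), exchanges the sulfonyl for a sulfanyl and lowers the number by a large amount, while the step from compound 2 to compound 3, an at least 19-fold higher number from compound 2 to compound 3 (1.29 log units; beyond the scatter), which restores a sulfonyl and removes the fluoro, raises it by a large amount. The step from compound 1 to compound 3, a step that the two limits leave unreadable from compound 1 to compound 3, cannot be read.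

Compound 4, `CC(O)(CSc1ccccc1)c1nc(-c2ccc([N+](=O)[O-])c(C(F)(F)F)c2)no1`, differs from compound 3 as follows: phenylsulfanyl in place of phenylsulfonyl on a saturated chain carbon, two bonds along the chain from an aromatic carbon and an oxygen on a saturated carbon. This is the same sulfonyl-to-sulfanyl exchange seen from compound 1 to compound 2, now without the fluoro. A large drop in this assay is therefore expected for compound 4, an at least 16-fold lower number from compound 3 to compound 4 (1.22 log units; beyond the scatter), toward the neighbourhood of compound 2. Compound 4 is estimated at 6000 nM, with a range of 2000 nM to 30000 nM.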

Compound 4, half-maximal inhibitory concentration: 3000 nM
For compound 4 the middle estimate is 2.0-fold (0.30 log units) above the measured one; measured number inside the range.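

With compound 4, the exchange of sulfonyl for sulfanyl at this saturated chain carbon is seen a second time, now without the fluoro: an at least 33-fold lower number from compound 3 to compound 4 (1.52 log units; beyond the scatter) in this assay, so the large step no longer rests on the fluorinated pair alone. The fluoro also gets its first readable comparison, a 1.7-fold lower number from compound 2 to compound 4 (0.23 log units; within the scatter), which means that among the two sulfanyl compounds, hydrogen in place of fluoro on an aromatic carbon does not shift the result beyond the usual scatter. The step of an at least 33-fold lower number from compound 1 to compound 4 (1.52 log units; beyond the scatter) points the same way, but this step and the one from compound 3 are bounds rather than full sizes, since each starts from a limit of the assay: the limit of > 100000 nM in this assay, at which 2 of the 4 values shown sit.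

The step between compound 1 and compound 3 still cannot be read, as both stand at that limit. As far as these compounds go, it also remains open whether an ether oxygen, a sulfinyl group or an amine nitrogen at the place of the sulfur would give values like those of compound 2 and compound 4, or whether a chloro or methoxy group on the phenyl ring would move them.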